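Mirror-image pair: a stereochemical inversion on the shared core

This account rests on a few compounds, and the source may have more. Where it says the series, first, only, none or still open, it means among the compounds named here.

Measured so far:
compound 1, `Cn1ncc(Cl)c1-c1cc(C(=O)N[C@@H]2CN[C@H](CCn3cncn3)C[C@H]2c2ccc(Cl)c(Cl)c2)oc1Cl`, 560 nM
compound 2, `Cn1ncc(Cl)c1-c1cc(C(=O)N[C@H]2CNCC[C@@H]2c2ccc(C(F)(F)F)cc2)oc1Cl`, 1050 nM

Both compounds were tested in a functional assay on HCT-116 cells (Homo sapiens) for antiproliferative activity, read by sulforhodamine B assay, with a stated time of 72 h; a higher number here means a weaker inhibitor, a lower number a stronger inhibitor. Compound 2 has the highest of the two numbers, with compound 1 the nearest at a value that lies within the scatter of the method, so the two cannot be told apart on these data. Within the data shown here, no step between two measured compounds that differ in one place is available here.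

Compound 3, `Cn1ncc(Cl)c1-c1cc(C(=O)N[C@@H]2CNCC[C@H]2c2ccc(C(F)(F)F)cc2)oc1Cl`, is the mirror image of compound 2: the two compounds have the same atoms and bonds and differ only in configuration as drawn: 2 of 2 stereo elements differ (all stereocentres are inverted: mirror images); a stereocentre at a saturated ring carbon is drawn R in compound 2 and S in compound 3; a stereocentre at a saturated ring carbon is drawn R in compound 2 and S in compound 3. For a pair of mirror images, one partner commonly turns out much stronger or much weaker than the other, but nothing measured here tells which way this pair will go. The direction of the expected step from compound 2 to compound 3 is therefore open, and the expected size is wide, as a 1.4-fold higher number from compound 2 to compound 3 (0.15 log units; within the scatter) shows. The value expected for compound 3 is 1500 nM, within a range from 100 nM to 20000 nM.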

Compound 3, half-maximal inhibitory concentration: 280 nM
The estimate for compound 3 lay 5.4-fold (0.73 log units) above the measured number; the range from low to high includes it.
By their numbers in this assay, from the lowest: compounds 3, 1 and 2 (each within the scatter of the next, the first and the last beyond it).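

Among these compounds, until now, the only two measured compounds differed in more than one place, so no single change could be read from them. In this assay, this pair supplies the first such reading, with inversion of both stereocentres giving a 3.8-fold lower number from compound 2 to compound 3 (0.57 log units; beyond the scatter). The difference can be assigned to configuration alone, because no atom or bond changes: the fact that compounds 2 and 3 differ only in the configuration as drawn. The step lies beyond the scatter, so the configuration at these saturated ring carbons does matter in this series, with the form drawn S at both centres giving the lower number, although the step is only modest in size.

Both stereocentres change together in this pair, so the compounds shown leave open whether one centre alone accounts for the step or both contribute. Going by these compounds, it also remains open whether the same preference between mirror images would hold with a nitrile in place of the trifluoromethyl group, since this one pair carries a single substituent and cannot establish a rule for the wider series.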